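Bromo at a second position on the aromatic ring

The source may hold more compounds than are shown below. What is called first, only, known or untested is meant among the compounds shown, and "the series" means these compounds.

Compound 1 `COC(=O)[C@@]1(C)CCC=C2[C@@H]1CC[C@@H](C)[C@]2(C)Cc1c(C)[nH]c2ccccc12` is the reference point of this short series. In a functional assay on SW1573 cells (Homo sapiens) for inhibition, read by sulforhodamine B assay, with a stated time of 48 h (a higher number here means a weaker inhibitor of growth, a lower number a stronger inhibitor of growth), compound 1 gives 14000 nM. Compound 2 `COC(=O)[C@@]1(C)CCC=C2[C@@H]1CC[C@@H](C)[C@]2(C)Cc1c(C)[nH]c2ccc(Br)cc12` carries bromo in place of hydrogen on an aromatic carbon, and in this assay compound 2 gives 14000 nM; the step of no change at the digits printed from compound 1 to compound 2 (within the scatter) shows that this substitution left the growth inhibition where it was, so compound 1 stands level with compound 2 within the scatter.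

Compound 3 `COC(=O)[C@@]1(C)CCC=C2[C@@H]1CC[C@@H](C)[C@]2(C)Cc1c(C)[nH]c2c(Br)cccc12` has not yet been measured. It differs from compound 1 in one place: bromo in place of hydrogen on an aromatic carbon. Among the measured compounds shown here, the only measured step that bears on this change is the one from compound 1 to compound 2 in this assay, which also introduced bromo on an aromatic carbon of the same fused system, though at a different position, and which was within the scatter. On that basis no step beyond the scatter is expected for compound 3 in this assay, that is no change at the digits printed from compound 1 to compound 3 (within the scatter). The estimate for compound 3 in this assay is therefore 14000 nM, with a range from 7000 nM to 28000 nM.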

Compound 3, concentration for 50% growth inhibition: 25000 nM
Compound 3: middle estimate off by 1.8-fold (0.25 log units), on the low side; the range from low to high includes it.
By their numbers in this assay, from the lowest: compounds 1, 2 and 3 (each within the scatter of the next).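

In this assay, the step for bromo in place of hydrogen on this aromatic carbon, ortho to a fused ring and meta to a fused ring, is a 1.8-fold higher number from compound 1 to compound 3 (0.25 log units; within the scatter), so the second position also gives no reading of a real shift in growth inhibition. Together with the earlier step, no change at the digits printed from compound 1 to compound 2 (within the scatter), this means that bromo on the six-membered aromatic ring has now been read at two positions in compounds 2 and 3, and neither step from compound 1 lies beyond the scatter. No supporting data bear on this result, so it stays a plain observation about these compounds.

The compounds shown leave open whether a different group on this aromatic carbon, such as an amine, a carboxylic acid or a methoxy group, would give a step beyond the scatter from compound 1. They also leave open whether any change away from the aromatic ring, such as a carboxylic acid in place of the methyl ester, would move the growth inhibition more than bromo does at either position.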